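The source may hold more compounds than are shown below. What is called first, only, known or untested is meant among the compounds shown, and "the series" means these compounds.

Measured in a functional assay on the whole organism (stomach) for inhibition, with Rattus norvegicus as the target; on this read-out higher numbers stand for an effect only at larger amounts of compound and lower numbers for an effect already at smaller amounts:
- Compound 1 `O=C(O)CCC/C=C1\CC2C[C@@H](O)[C@H](/C=C/[C@@H](O)c3ccc4c(c3)OCCO4)C2C1`: > 0.3 mg/kg
- Compound 2 `O=C(O)CCC/C=C1\CC2C[C@@H](O)[C@H](/C=C/[C@@H](O)CC3COc4ccccc4O3)C2C1`: > 0.3 mg/kg

Compound 1 stands at the limit of > 0.3 mg/kg in this assay, at which 2 of the 2 values shown sit. That value is a limit, not an exact number.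

Compound 3 `CC1([C@H](O)/C=C/[C@@H]2C3C/C(=C/CCCC(=O)O)CC3C[C@H]2O)Cc2ccccc2C1` carries 2-methyl-2,3-dihydro-1H-inden-2-yl in place of 2,3-dihydro-1,4-benzodioxin-6-yl, on a saturated chain carbon bound to a double-bonded chain carbon and an oxygen on a saturated carbon: 2-methyl-2,3-dihydro-1H-inden-2-yl in place of 2,3-dihydro-1,4-benzodioxin-6-yl on a saturated chain carbon bound to a double-bonded chain carbon and an oxygen on a saturated carbon.

Going by the values given here, no measured pair shows what such a swap does in this assay. Going by these compounds, the expected step of a number no higher from compound 1 to compound 3 (the limit leaves the size open) is none beyond the scatter, and its direction remains open. Compound 3 is estimated at 0.3 mg/kg, with an expected range of 0.06 mg/kg to 1.5 mg/kg.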

Compound 3, dose for half-maximal effect: 0.0452 mg/kg
Estimate against measurement, compound 3: 6.6-fold (0.82 log units) above, and the stated range ends above it.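

In this assay, replacing 2,3-dihydro-1,4-benzodioxin-6-yl with 2-methyl-2,3-dihydro-1H-inden-2-yl gives an at least 6.6-fold lower number from compound 1 to compound 3 (0.82 log units; beyond the scatter), so a change of group at this position can move the number beyond the scatter. Compound 3 provides the first exact value here, whereas compound 1 and compound 2 offered only a limit: the limit of > 0.3 mg/kg in this assay, at which 2 of the 3 values shown sit.

This single swap removes the ring oxygens, changes the ring size and adds a methyl all at once, leaving their separate contributions unresolved. Also open, going by these compounds, is how the same ring without its methyl, or a phenyl ring carrying an amine, would read out.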